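Removing the methoxyethoxy chain from compound 3 for a methyl

A few compounds are considered here, and "the series" means these few. Any claim that something is new, unique, unknown or untested is made for them only; others in the source may bear on it.

The three quinoline-like acids measured so far share the same core and differ only at one aromatic carbon. Compound 1 `Nc1ccc2nccc(SC3(C(=O)O)CCC3)c2c1` gives 1790 nM in an assay on HEK293 cells for inhibition of solute carrier family 22 member 12 (Homo sapiens), read by scintillation counting, with a stated time of 12 min (a higher number here means a weaker inhibitor, a lower number a stronger inhibitor), compound 2 `N#CCCc1ccc2nccc(SC3(C(=O)O)CCC3)c2c1` gives 2760 nM, and compound 3 `COCCOc1ccc2nccc(SC3(C(=O)O)CCC3)c2c1` gives 207 nM. Compound 3 thus stands at the lowest number of the three, with an 8.6-fold lower number from compound 1 to compound 3 (0.94 log units; beyond the scatter) and a 13-fold lower number from compound 2 to compound 3 (1.12 log units; beyond the scatter); the step of a 1.5-fold higher number from compound 1 to compound 2 (0.19 log units; within the scatter) separates the other two only within the usual scatter.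

Compound 4 `Cc1ccc2nccc(SC3(C(=O)O)CCC3)c2c1` replaces this group: methyl in place of 2-methoxyethoxy on an aromatic carbon. Among the measured compounds shown here, no measured step starts from a methyl, so both earlier steps bear only by analogy. They show that the two substituents other than the 2-methoxyethoxy sit at clearly higher numbers, and compound 3 alone reaches the low value. A methyl is expected to behave more like those two, so an expected rise in this assay of a 7.2-fold higher number from compound 3 to compound 4 (0.86 log units; beyond the scatter) follows. Compound 4 is therefore estimated at 1500 nM, with a range from 500 nM to 4500 nM.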

Compound 4, half-maximal inhibitory concentration: 343 nM
For compound 4 the middle estimate is 4.4-fold (0.64 log units) above the measured one; the whole stated range lies above it.
By their numbers in this assay, from the lowest: compounds 3 and 4 (each within the scatter of the next); then compounds 1 and 2 (each within the scatter of the next).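

In this assay, methyl and 2-methoxyethoxy on this aromatic carbon cannot be told apart (a 1.7-fold higher number from compound 3 to compound 4 (0.22 log units; within the scatter)), so the low number does not depend on the 2-methoxyethoxy chain or its hydrogen-bond acceptors. Amino and 2-cyanoethyl are now set apart from both of these groups rather than 2-methoxyethoxy alone: methyl in place of 2-cyanoethyl gives an 8.0-fold lower number from compound 2 to compound 4 (0.91 log units; beyond the scatter) and methyl in place of amino gives a 5.2-fold lower number from compound 1 to compound 4 (0.72 log units; beyond the scatter), both beyond the scatter. No measured evidence accounts for these differences.

The compounds shown leave open whether a bare hydrogen or an ethyl at this aromatic carbon would fall with methyl and 2-methoxyethoxy or with amino and 2-cyanoethyl. They also leave open where a longer ether chain, a carboxylic acid or a dimethylamino group would fall.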